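The source may hold more compounds than are shown below. What is called first, only, known or untested is meant among the compounds shown, and "the series" means these compounds.

Compound 1 `CCOc1ccc(/C=C(\C(=O)c2ccc(Cl)cc2)S(=O)(=O)Cc2ccc(C)cc2)cc1OC`: 10000 nM
Compound 2 `CCOc1ccc(/C=C(\C(=O)c2ccc(Br)cc2)S(=O)(=O)c2ccc(C)cc2)cc1OC`: 1000 nM

Among the compounds with values here, in a functional assay on DU-145 cells (Homo sapiens) for inhibition, read by trypan blue exclusion, with a stated time of 96 h (a lower number here means a stronger inhibitor of growth, a higher number a weaker inhibitor of growth), compound 2 gives 1000 nM, the lower of the two numbers so far. Compound 1 gives 10000 nM, and that gap lies beyond the usual scatter of repeated measurements. Compound 2 is therefore the stronger growth inhibitor of the measured pair.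

The next compound to be tested is compound 3 `CCOc1ccc(/C=C(\C(=O)c2ccc(Cl)cc2)S(=O)(=O)c2ccc(C)cc2)cc1OC`. It is compound 2 with chloro in place of bromo on an aromatic carbon. The two structures differ only in this one atom, which sits para to a large group.

Within the data shown here, no measured pair shows this swap on its own, so the data give no direct guide to its size. The expectation therefore starts from compound 2 at 1000 nM and assumes that so small a change leaves the number close to where it stands. The expected change is no change at the digits printed from compound 2 to compound 3 (within the scatter), with no shift beyond the scatter anticipated in either direction. For compound 3 the estimated value is 1000 nM, with an expected range from 300 nM to 4000 nM.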

Compound 3, concentration for 50% growth inhibition: 1000 nM
Beside the measured number, compound 3's estimate shows no gap at the digits printed; the measured number falls inside the stated range.
By their numbers in this assay, from the lowest: compounds 2 and 3 (each within the scatter of the next); then compound 1.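

In this assay the step of no change at the digits printed from compound 2 to compound 3 (within the scatter) comes with chloro in place of bromo on an aromatic carbon, para to a large group, so these two halogens cannot be told apart at this place in this series. Compound 3 also makes the sulfonyl side readable on its own: compound 1 and compound 2 differ in two places, which left the gap between them unassigned, whereas 4-methylphenyl in place of 4-methylbenzyl on the sulfonyl sulfur gives a 10-fold lower number from compound 1 to compound 3 (1.00 log units; beyond the scatter) with the halogen held as chloro. No separate measurement here bears on why either step turned out as it did.

The compounds shown carry only chloro or bromo at the halogen place, so a methoxy group, an amine or a plain hydrogen there remains an open comparison. On the sulfonyl sulfur only 4-methylphenyl and 4-methylbenzyl appear, leaving open how a longer chain such as 2-phenylethyl, or a carboxylic acid on that ring, would read in this assay for this core.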